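The compounds below may be only part of what the source reports. "The series", "measured", "known", "first", "only" and "open" are said of these compounds alone.

Measured so far:
- compound 1 `O=C(Nc1ccc(C(F)(F)F)cc1)c1cc(F)ccc1O`: 580 nM
- compound 2 `N#Cc1ccc(NC(=O)c2ccc3cccnc3c2O)c(F)c1`: 420 nM

Both values come from a functional assay on Jurkat cells (Homo sapiens) for cytotoxicity, read by luminescence and CellTiter-Glo, with a stated time of 3 days; on this read-out lower numbers stand for stronger inhibition and higher numbers for weaker inhibition. There, compound 2 gives 420 nM and compound 1 gives 580 nM. These two numbers lie within the usual scatter of repeated measurements, so they cannot be ranked and the two compounds count as alike on this read-out.

The next compound to be tested is compound 3 `N#Cc1ccc(NC(=O)c2ccc3cccnc3c2O)cc1`, which differs from compound 2 in one place: hydrogen in place of fluoro on an aromatic carbon. In words, hydrogen takes the place of fluoro on an aromatic carbon, and the rest of the structure stays the same.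

Among the measured compounds shown here, no pair of measured compounds shows this change, so the data give no direct guide to its size or direction in this assay. Compound 2, at 420 nM, is the closest reference available, and the estimate stays near it. The expected change is a 1.2-fold higher number from compound 2 to compound 3 (0.08 log units; within the scatter), which would not go beyond the scatter. For compound 3 the estimated value is 500 nM, with an expected range from 170 nM to 1500 nM.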

Compound 3, half-maximal inhibitory concentration: 180 nM
For compound 3 the middle estimate is 2.8-fold (0.44 log units) above the measured one; low and high end bracket the measured number.
By their numbers in this assay, from the lowest: compound 3; then compounds 2 and 1 (each within the scatter of the next).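

Hydrogen in place of fluoro on an aromatic carbon, ortho to a large group and meta to a cyano group, gives a 2.3-fold lower number from compound 2 to compound 3 (0.37 log units; beyond the scatter) in this assay. Among the compounds shown here, this is the first step that goes beyond the scatter, and it shows that this position is not indifferent to what sits on it: a single fluorine atom, with the rest of the structure unchanged, is enough to shift the number, and the fluoro is not needed to reach the lowest number of the three compounds. Nothing among the available data gives a reason for this shift.

Going by these compounds, with only fluoro and hydrogen compared at this position, it remains open whether a chlorine atom, a methoxy group or an amine there would give a lower number, a higher one or about the same. On these data alone, it is also open whether hydrogen in place of fluoro would have a similar effect at other positions on this ring, or on a different core such as that of compound 1.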